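Cytotoxicity on Vero cells before compound 4 is measured

A few compounds are considered here, and "the series" means these few. Any claim that something is new, unique, unknown or untested is made for them only; others in the source may bear on it.

Measured so far:
Compound 1 `CN(C)c1cc2[nH]c(C3CCCCC3)nc2cc1NC(=O)OCc1ccccc1`: in an ADME assay on Vero cells (Chlorocebus sabaeus) for cytotoxicity, read by resazurin assay, with a stated time of 3 days (on this read-out lower numbers stand for stronger inhibition and higher numbers for weaker inhibition), compound 1 gives only a limit of the assay, > 100 ug/mL.
Compound 2 `CCCN(CCC)c1cc2[nH]c(C3CCCCC3)nc2cc1NC(=O)OCc1ccccc1`: in this assay compound 2 gives a limit of the assay, > 100 ug/mL.
Compound 3 `CCOc1ccc(C(=O)Nc2cc3nc(C4CCCCC4)[nH]c3cc2N(CC)CC)cc1`: in this assay compound 3 gives a limit of the assay, > 100 ug/mL.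

Compound 1 stands at a limit, so no number is known for it; the same holds for the two other compounds shown, as the limit of > 100 ug/mL in this assay, at which 3 of the 3 values shown sit, states. Among the compounds with values here, the only single-site step among them, a step that the two limits leave unreadable from compound 1 to compound 2, cannot be read because both ends are limits. Compound 4 `CCCCCC(=O)Nc1cc2nc(C3CCCCC3)[nH]c2cc1N(C)C` differs from compound 1 in one place: pentyl in place of benzyloxy on a carbonyl carbon. Within the data shown here, no measured step covers this change, so the known compounds give no direction, and the expectation is a step in this assay of a number no higher from compound 1 to compound 4 (the limit leaves the size open), that is, none beyond the scatter. Compound 4 is therefore expected to give about 100 ug/mL in this assay, within a range from 40 ug/mL to 250 ug/mL, most likely reported again as a limit.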

Compound 4, half-maximal inhibitory concentration: > 100 ug/mL
Compound 4: only a limit was reported; the forecaster's own chance of this, stated with the estimate: 70%; the middle value lies on the limit itself.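

Compound 4, like compound 1, gives only a limit, so swapping benzyloxy for pentyl yields no readable step in this assay: the limit of > 100 ug/mL in this assay, at which 4 of the 4 values shown sit.

The compounds shown leave open the actual concentration at which each harms these cells, and whether any of these changes alters it.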